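The compounds below may be only part of what the source reports. "The series", "measured", "known", "first", "only" and "open" are said of these compounds alone.

Compound 3 `CCn1c(C(=O)Oc2ccc(CCO)cc2)ccc1C(CC)(CC)c1ccc(OCC(O)C(C)(C)C)c(C)c1` carries an ester on the shared core. For the measured compounds named here, in an assay on HL-60 cells for agonist activity at vitamin D3 receptor (Homo sapiens), read by microscopy, with a stated time of 96 h (on this read-out lower numbers stand for an effect already at smaller amounts and higher numbers for an effect only at larger amounts of compound), compound 3 gives 5100 nM, one of only two plain numbers here. Compound 1 `C=CCN(C)C(=O)c1ccc(C(CC)(CC)c2ccc(OCC(O)C(C)(C)C)c(C)c2)n1CC` gives 3950 nM in this assay, and a 1.3-fold higher number from compound 1 to compound 3 (0.11 log units; within the scatter), so the two sit together. Compound 2 `CCn1c(C(=O)Nc2cccc(C(F)(F)F)c2)ccc1C(CC)(CC)c1ccc(OCC(O)C(C)(C)C)c(C)c1` gives > 50000 nM in this assay, which is a limit and not a number (the limit of > 50000 nM in this assay, at which 1 of the 3 values shown sits). The steps of an at least 12-fold higher number from compound 1 to compound 2 (1.10 log units; beyond the scatter) and an at least 9.8-fold lower number from compound 2 to compound 3 (0.99 log units; beyond the scatter) show that a change on the carbonyl carbon can matter greatly. Compound 4 `CCn1c(C(=O)OCc2ccccn2)ccc1C(CC)(CC)c1ccc(OCC(O)C(C)(C)C)c(C)c1` differs from compound 3 by (pyridin-2-yl)methyl in place of 4-(2-hydroxyethyl)phenyl on an oxygen next to a carbonyl group. Going by the values given here, the ester itself remains, and the one change that kept an ester or amide, from compound 1 to compound 3, stayed within the scatter; a small step is therefore expected, a 1.0-fold lower number from compound 3 to compound 4 (0.01 log units; within the scatter). Compound 4 is estimated at 5000 nM, between 1500 nM and 20000 nM.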

Compound 4, half-maximal effective concentration: > 50000 nM
Compound 4 ended at the assay's limit; the forecaster's own chance of this, stated with the estimate: 15%; middle value at least 10-fold (1.00 log units) from the limit.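

Keeping the ester does not by itself preserve the effect: with (pyridin-2-yl)methyl in place of 4-(2-hydroxyethyl)phenyl, the result is an at least 9.8-fold higher number from compound 3 to compound 4 (0.99 log units; beyond the scatter). Measured against the allyl(methyl)amino amide, the change to (pyridin-2-yl)methoxy gives an at least 12-fold higher number from compound 1 to compound 4 (1.10 log units; beyond the scatter), so the group on the ester oxygen can matter as much as the change seen with the anilide. Compound 4 gives a limit and not a number, and its step to compound 2 cannot be read: the limit of > 50000 nM in this assay, at which 2 of the 4 values shown sit.

The compounds shown do not separate losing the 2-hydroxyethyl chain from gaining the pyridine ring. A plain phenyl ester and a benzyl ester would help tell these two changes apart.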